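The source may report more compounds than this note shows. Statements on the series, on what has been measured and on what is new or still open speak of the compounds shown alone.

Measured compounds:
compound 1, `COc1cc(/C=C/C(=O)/C=C(/C=C/c2ccc(OC(C)=O)c(OC)c2)NC2CCCCC2)ccc1OC(C)=O`, 0.01%
compound 2, `CCC(C)NC(=C\C(=O)/C=C/c1ccc(O)c(OC)c1)/C=C/c1ccc(O)c(OC)c1`, 0.13%

The account follows compound 2 into an untested variant. In a functional assay for inhibition, read by spectrophotometry, with a stated time of 30 min, tested at 1 uM (a lower number here means less inhibition, a higher number more inhibition at the concentration tested (going by the name of the read-out)), compound 2 gives 0.13%, and compound 1 gives 0.01% in the same assay. The two numbers lie within the usual scatter of each other, so neither compound can be set apart from the other on this read-out; both show only a trace of inhibition at the concentration tested.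

Compound 3, `COc1cc(/C=C/C(=O)/C=C(/C=C/c2ccc(O)c(OC)c2)NCC(C)C)ccc1O`, has not yet been run in this assay. It keeps the core of compound 2 and differs in one place: isobutyl in place of sec-butyl on an amine nitrogen. Among the compounds with values here, the two measured compounds give no direct step to lean on, and the reshuffling of a four-carbon chain on the amine nitrogen offers no ground to expect a move beyond the scatter. Compound 3 is therefore expected to stay near compound 2, with a step of a number 0.1 percentage points higher from compound 2 to compound 3 (within the scatter) in this assay. The estimate for compound 3 in this assay is 0.2%, with a range from -6% to 8%.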

Compound 3, a percentage reported as inhibition, at one concentration (the size of the read-out at that concentration, not a potency): 0.09%
Beside the measured number, compound 3's estimate is 0.1 percentage points above it; the measured number falls inside the stated range.
By their numbers in this assay, from the lowest: compounds 1, 3 and 2 (each within the scatter of the next).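

In this assay, within the data shown here, isobutyl in place of sec-butyl on the amine nitrogen gives a number 0 percentage points lower from compound 2 to compound 3 (within the scatter) and provides the first direct comparison at this position. The two four-carbon chains cannot be told apart on this read-out, and both compounds show only a trace of inhibition at the concentration tested. Nothing shown here explains this result.

The compounds shown leave open whether a different group on this nitrogen, such as a longer chain, a benzyl group or a chain ending in a carboxylic acid, would give a number beyond the scatter of these two. They also leave open whether compound 2 and compound 3 would differ at a higher concentration, since a single concentration at which both barely register says little about how they might compare elsewhere.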